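This account rests on a few compounds, and the source may have more. Where it says the series, first, only, none or still open, it means among the compounds named here.

Measured so far in a functional assay on A375P cells (Homo sapiens) for antiproliferative activity, read by MTT assay, with a stated time of 24 h; on this read-out lower numbers stand for stronger inhibition and higher numbers for weaker inhibition:

Compound 1 `CC(=O)Nc1ncnc2c1ccn2-c1ccc(NC(=O)Nc2ccc(Cl)c(C(F)(F)F)c2)cc1`: > 10000 nM. This value is a limit of the assay, not a number.
Compound 2 `Nc1ncnc2c1ccn2-c1ccc(NC(=O)Nc2ccc(Cl)c(C(F)(F)F)c2)cc1`: 8100 nM.
Compound 3 `Nc1ncnc2c1ccn2-c1ccc(NC(=O)c2ccc(Cl)c(C(F)(F)F)c2)cc1`: 2900 nM.

Compound 4 `CC(=O)Nc1ncnc2c1ccn2-c1ccc(NC(=O)c2ccc(Cl)c(C(F)(F)F)c2)cc1` is not yet measured. Of the two numbers read, compound 3 gives the lower, and compound 2 stands a step beyond the scatter from it; the difference between the two cores is not broken down here. From compound 2 to compound 1 the change is acetyl in place of hydrogen on a nitrogen on an aromatic ring, and it gave an at least 1.2-fold higher number from compound 2 to compound 1 (0.09 log units; that floor lies within the scatter), a floor set by the limit (the limit of > 10000 nM in this assay, at which 1 of the 3 values shown sits). The same change, (acetyl in place of hydrogen on a nitrogen on an aromatic ring), is made from compound 3 to compound 4, at a place described in the same words. A weakening step, a 2.4-fold higher number from compound 3 to compound 4 (0.38 log units; beyond the scatter), is therefore expected, resting on the direction seen in compound 1 at the limit of > 10000 nM in this assay, at which 1 of the 3 values shown sits. Compound 4 is estimated at 7000 nM, expected between 3500 nM and 15000 nM.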

Compound 4, half-maximal inhibitory concentration: > 10000 nM
Compound 4 ended at the assay's limit; the forecaster's own chance of this, stated with the estimate: 30%; middle value at least 1.4-fold (0.15 log units) from the limit.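

In this assay compound 4 gives > 10000 nM as a limit of the assay, not a number. Acetyl in place of hydrogen on a nitrogen on an aromatic ring gives an at least 3.4-fold higher number from compound 3 to compound 4 (0.53 log units; beyond the scatter) on the core of compound 3, so the change weakens this core by a margin that can be read. On the two cores together, this shows that the change brought no gain in either case, but not that it costs the same amount on each: the same change on two cores in this assay, an at least 1.2-fold higher number (0.09 log units; that floor lies within the scatter) from compound 2 to compound 1 and an at least 3.4-fold higher number (0.53 log units; beyond the scatter) from compound 3 to compound 4; the limit leaves it open whether they differ.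

From the compounds shown here alone, whether a methyl group or a longer acyl chain such as propionyl on that nitrogen behaves as acetyl does stays open. The compounds shown carry only hydrogen or acetyl there.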